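This account rests on a few compounds, and the source may have more. Where it says the series, first, only, none or still open, it means among the compounds named here.

Working notes on the series. The shared core carries a nitrile and a phenyl group; compound 3 `N#Cc1c(Nc2ccc(Cl)cc2)nc(SCc2cn(Cc3ccccc3Cl)nn2)nc1-c1ccccc1` differs from compound 1 `C#CCSc1nc(Nc2ccc(OC)cc2)c(C#N)c(-c2ccccc2)n1` and compound 2 `C#CCSc1nc(Nc2ccc(Cl)cc2)c(C#N)c(-c2ccccc2)n1` both in the group on the sulfur and in the ring on the nitrogen. In a functional assay on MCF7 cells (Homo sapiens) for inhibition, read by MTT assay, with a stated time of 72 h (a higher number here means a weaker inhibitor, a lower number a stronger inhibitor), compound 3 gives 6520 nM, the lowest of the two numbers shown, while compound 1 gives 35600 nM. Compound 2 reaches only the limit > 128000 nM. Compound 2 thus sits at the limit of > 128000 nM in this assay, at which 1 of the 3 values shown sits. Going by the values given here, on the ring on the nitrogen the one measured step is an at least 3.5-fold higher number from compound 1 to compound 2 (0.55 log units; beyond the scatter). Among the compounds with values here, compound 4 `N#Cc1c(Nc2ccccc2F)nc(SCc2cn(Cc3ccccc3Cl)nn2)nc1-c1ccccc1` carries 2-fluorophenyl in place of 4-chlorophenyl on a nitrogen on an aromatic ring; no measured pair exchanges halogens on this ring, so the measured step only shows that a substituent change there can move the number modestly. A modest step, direction open, is expected: a 1.2-fold higher number from compound 3 to compound 4 (0.09 log units; within the scatter). Compound 4 is estimated at 8000 nM, between 2500 nM and 25000 nM.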

Compound 4, half-maximal inhibitory concentration: 8060 nM
Compound 4: the middle estimate sits 1.0-fold (0.00 log units) below what was measured, within the range that was stated.
By their numbers in this assay, from the lowest: compounds 3 and 4 (each within the scatter of the next); then compound 1. At a limit, above all of these: compound 2.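

In this assay, 2-fluorophenyl in place of 4-chlorophenyl on a nitrogen on an aromatic ring gives a 1.2-fold higher number from compound 3 to compound 4 (0.09 log units; within the scatter). With the group on the sulfur held constant, these two halogen-bearing rings cannot be told apart, whereas the earlier step on this ring, chloro in place of methoxy, carried a different group on the sulfur and lay beyond the scatter. No measured property shown here bears on this step. From the compounds shown here alone, whether an amine or a carboxylic acid on this ring would move the number remains open. So does whether 2-fluorophenyl matches 4-chlorophenyl with the group on the sulfur of compound 2.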